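Taking One Methoxy Group Away from Compound 2

This account rests on a few compounds, and the source may have more. Where it says the series, first, only, none or still open, it means among the compounds named here.

In a functional assay on UACC-62 cells (Homo sapiens) for inhibition, read by sulforhodamine B assay, with a stated time of 48 h (a lower number here means a stronger inhibitor of growth, a higher number a weaker inhibitor of growth), compound 2 (`COc1ccc(/C=C/C2(C)C=CC(=O)O2)cc1OC`) gives 84100 nM. Two relatives offer a comparison: compound 1 (`CC1(/C=C/c2ccccc2)C=CC(=O)O1`) gives 97200 nM, and compound 3 (`COc1ccc(/C=C/C2(C)C=CC(=O)O2)c(OC)c1OC`) gives 71500 nM. Compound 2 lies within the scatter of both, so the three numbers set up no real order.

Compound 4 (`COc1cccc(/C=C/C2(C)C=CC(=O)O2)c1`) differs from compound 2 by hydrogen in place of methoxy on an aromatic carbon. Going by the values given here, only one measured step involves a single methoxy change, and it runs the opposite way, adding the group at a different place on the ring. That step, a 1.2-fold lower number from compound 2 to compound 3 (0.07 log units; within the scatter), stays within the scatter. Compound 1, which also has hydrogen on the carbon in question and carries no methoxy group at all, gives a number close to that of compound 2. No step beyond the scatter is therefore expected, and the estimate is a 1.1-fold higher number from compound 2 to compound 4 (0.03 log units; within the scatter). Compound 4 is expected to give about 90000 nM, with an estimated range from 58000 nM to 140000 nM.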

Compound 4, concentration for total growth inhibition: 55800 nM
Beside the measured number, compound 4's estimate is 1.6-fold (0.21 log units) above it; the measured number lies below the stated range.
By their numbers in this assay, from the lowest: compounds 4, 3, 2 and 1 (each within the scatter of the next).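

Removing the methoxy group that sits ortho to a methoxy group and para to a group of 9 heavy atoms gives a 1.5-fold lower number from compound 2 to compound 4 (0.18 log units; within the scatter) and so shows that the number at this position does not depend on that group. Going by these compounds alone, compound 4 also shows a single methoxy group on the ring for the first time, and placing it on the core of compound 1 gives a 1.7-fold lower number from compound 1 to compound 4 (0.24 log units; within the scatter) with no step beyond the scatter. Adding a methoxy group reads alike in both settings: (the same change on two cores in this assay, a 1.2-fold lower number (0.07 log units; within the scatter) from compound 2 to compound 3 and a 1.7-fold lower number (0.24 log units; within the scatter) from compound 1 to compound 4, 1.5-fold (0.17 log units) apart, within the scatter of two such steps).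

On the ring, the compounds shown carry only hydrogen or methoxy, so what an amine or a carboxylic acid at this position would do stays open. From the compounds shown here alone, whether a longer chain in place of the methoxy group would give a step beyond the scatter also stays open.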